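Trifluoromethyl in place of pyridinyl on the shared core

The compounds below may be only part of what the source reports. "The series", "measured", "known", "first", "only" and "open" are said of these compounds alone.

Measured compounds:
compound 1, `CC1(C)C=C(n2ccccc2=O)c2cc(C(=O)c3ccc(O)cc3)ccc2O1`, 5.87
compound 2, `CC1(C)C=C(n2ccccc2=O)c2cc(C#N)ccc2O1`, 7.1
compound 3, `CC1(C)C=C(n2ccccc2=O)c2cc(-c3ccncc3)ccc2O1`, 6.32

In a functional assay (trachea) with Rattus norvegicus as the target (on this read-out higher numbers stand for higher potency (the scale is a negative logarithm) and lower numbers for lower potency), compound 3 stands second of the three measured compounds: its number is a number 0.45 log units higher from compound 1 to compound 3 (beyond the scatter) and a number 0.78 log units lower from compound 2 to compound 3 (beyond the scatter). Compound 4, `CC1(C)C=C(n2ccccc2=O)c2cc(C(F)(F)F)ccc2O1`, differs from compound 3 in one place: trifluoromethyl in place of pyridin-4-yl on an aromatic carbon. Going by the values given here, two measured steps bear on this change. The step of a number 1.23 log units higher from compound 1 to compound 2 (beyond the scatter) shows that replacing the (4-hydroxyphenyl)carbonyl on this aromatic carbon with cyano raised potency greatly, and the step of a number 0.78 log units lower from compound 2 to compound 3 (beyond the scatter) shows that pyridin-4-yl at the same position falls well short of cyano. Since compound 4 carries trifluoromethyl rather than a six-membered aromatic ring at that position, the account expects the number to move upward from compound 3, beyond the scatter, though not necessarily all the way to compound 2. Compound 4 is therefore expected to show a number 0.48 log units higher from compound 3 to compound 4 (beyond the scatter), which corresponds to an estimated value of 6.8 with a range from 6.2 to 7.4.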

Compound 4, logarithm of the reciprocal of the active concentration, log(1/C): 7.37
Estimate against measurement, compound 4: 0.57 log units below; the range from low to high includes it.
By their numbers in this assay, from the lowest: compound 1; then compound 3; then compounds 2 and 4 (each within the scatter of the next).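

In this assay, trifluoromethyl in place of pyridin-4-yl gives a number 1.05 log units higher from compound 3 to compound 4 (beyond the scatter), and in place of (4-hydroxyphenyl)carbonyl it gives a number 1.50 log units higher from compound 1 to compound 4 (beyond the scatter), so a group with no ring on this aromatic carbon can carry the number well past both ring-bearing groups. Trifluoromethyl in place of cyano gives a number 0.27 log units higher from compound 2 to compound 4 (within the scatter), so these two ring-free groups cannot be told apart here, and among the four compounds, none goes against the split between ring-free and ring-bearing groups. Nothing given here accounts for this split.

On these data alone, it remains open whether an amine, a carboxylic acid or a longer alkyl chain on this carbon would stay level with trifluoromethyl and cyano. As far as these compounds go, it is also open whether a phenyl ring or another ring-bearing group would fall with pyridin-4-yl.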